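The source may report more compounds than this note shows. Statements on the series, on what has been measured and on what is new or still open speak of the compounds shown alone.

Among the two compounds measured so far in a functional assay on isolated protein for inhibition of Glucose-dependent insulinotropic receptor (Rattus norvegicus), read by HTRF and cAMP accumulation (a higher number here means that more compound is needed for the effect, a lower number that less compound is needed), compound 2 `Cc1nc(S(C)(=O)=O)ccc1Oc1ncnc(OC2CCN(C(=O)C(C)(C)F)CC2)c1F` stands at the higher number: compound 2 gives 296 nM, while compound 1 `Cc1nc(S(C)(=O)=O)ccc1Oc1ncnc(OC2CCN(C(=O)OC(C)(C)C(F)(F)F)CC2)c1F` gives 47.2 nM. Among the compounds with values here, the single step joining them, a 6.3-fold higher number from compound 1 to compound 2 (0.80 log units; beyond the scatter), lies beyond the scatter and shows that the group on this carbonyl carbon matters for the read-out. Compound 3 `Cc1nc(S(C)(=O)=O)ccc1Oc1ncnc(OC2CCN(C(=O)c3noc(C(C)C)n3)CC2)c1F` awaits measurement in this assay. It differs from compound 2 in one place: 5-isopropyl-1,2,4-oxadiazol-3-yl in place of 1-fluoro-1-methylethyl on a carbonyl carbon. Within the data shown here, only one measured step bears on this position, namely a 6.3-fold higher number from compound 1 to compound 2 (0.80 log units; beyond the scatter), and it is of modest size; it says nothing directly about an aromatic ring at this carbonyl, so the direction for compound 3 rests on the observation that the larger group in compound 1 went with the lower number. On that basis compound 3 is expected to land at a lower number than compound 2, by a modest step. For compound 3 the expected step is a 3.7-fold lower number from compound 2 to compound 3 (0.57 log units; beyond the scatter). Compound 3 is therefore estimated at 80 nM, with a range from 25 nM to 300 nM.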

Compound 3, half-maximal effective concentration: 176 nM
Compound 3: the middle estimate sits 2.2-fold (0.34 log units) below what was measured; the range from low to high includes it.
By their numbers in this assay, from the lowest: compound 1; then compounds 3 and 2 (each within the scatter of the next).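

In this assay, the step of a 1.7-fold lower number from compound 2 to compound 3 (0.23 log units; within the scatter) shows that a five-membered aromatic ring with 3 hetero atoms can take the place of 1-fluoro-1-methylethyl on this carbonyl carbon with no difference that stands clear of the scatter, although 5-isopropyl-1,2,4-oxadiazol-3-yl brings more heavy atoms and hydrogen-bond acceptors where the group it replaces has none. The step of a 3.7-fold higher number from compound 1 to compound 3 (0.57 log units; beyond the scatter) leaves compound 1 apart from both other compounds, so a larger group than 1-fluoro-1-methylethyl does not in itself match 1-methyl-1-(trifluoromethyl)ethoxy, which among these three groups is the only one joined to the carbonyl carbon through oxygen. Nothing at hand explains why these groups compare as they do.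

The compounds shown leave open whether the oxygen of 1-methyl-1-(trifluoromethyl)ethoxy or its trifluoromethyl group goes with the lower number, a question that a tert-butoxy group or a secondary amine nitrogen in place of that oxygen would address. They also leave open how the oxadiazole would compare with a phenyl ring, and whether a cyclopropyl or tert-butyl group in place of its isopropyl would shift the read-out.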